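Dropping a Nitro Group Next to a Phenol Amide

The source may hold more compounds than are shown below. What is called first, only, known or untested is meant among the compounds shown, and "the series" means these compounds.

Of the compounds shown here, three built on one shared core have been measured in a functional assay on CLL cells (Homo sapiens) for cytotoxicity, read by MTT assay, with a stated time of 48 h; a higher number here means that more compound is needed for the effect, a lower number that less compound is needed. Compound 1 `C=C(CC)C(=O)c1ccc(OCC(=O)Nc2nc3ccccc3s2)c(Cl)c1Cl` gives 1500 nM. Among the compounds with values here, compound 2 `C=C(CC)C(=O)c1ccc(OCC(=O)Nc2ccc(C(=O)O)cc2)c(Cl)c1Cl` gives 5000 nM, and the only one-place step among the measured compounds, a 3.3-fold higher number from compound 1 to compound 2 (0.52 log units; beyond the scatter), concerns the group on the amide-type nitrogen. Compound 3 `C=C(CC)C(=O)c1ccc(OCC(=O)Nc2ccc(O)c([N+](=O)[O-])c2)c(Cl)c1Cl` gives 7400 nM, the highest of the three numbers; its gap to compound 2 lies within the scatter, while its gap to compound 1 lies beyond it.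

Compound 4 `C=C(CC)C(=O)c1ccc(OCC(=O)Nc2ccc(O)cc2)c(Cl)c1Cl` differs from compound 3 in a single place: hydrogen in place of nitro on an aromatic carbon. The change sits on an aromatic carbon of a six-membered aromatic ring of carbon only, ortho to a hydroxy group and meta to a large group. Within the data shown here, no measured step touches that ring, so there is no direct guide, and the expectation is a step within the scatter. Compound 4 is therefore estimated at 6000 nM, with a range from 2500 nM to 15000 nM. The expected step is a 1.2-fold lower number from compound 3 to compound 4 (0.09 log units; within the scatter).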

Compound 4, half-maximal effective concentration: 6400 nM
Beside the measured number, compound 4's estimate is 1.1-fold (0.03 log units) below it; low and high end bracket the measured number.
By their numbers in this assay, from the lowest: compound 1; then compounds 2, 4 and 3 (each within the scatter of the next).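

In this assay, within the data shown here, the nitro group ortho to a hydroxy group can go with no difference the assay can separate from scatter: hydrogen in its place gives a 1.2-fold lower number from compound 3 to compound 4 (0.06 log units; within the scatter) and is the first measured step on this ring. Hydroxy in place of carboxy gives a 1.3-fold higher number from compound 2 to compound 4 (0.11 log units; within the scatter), so these two compounds cannot be told apart either, whereas 4-hydroxyphenyl in place of 1,3-benzothiazol-2-yl on the amide-type nitrogen gives a 4.3-fold higher number from compound 1 to compound 4 (0.63 log units; beyond the scatter) and lies beyond the scatter, as did a 3.3-fold higher number from compound 1 to compound 2 (0.52 log units; beyond the scatter) before it. Nothing at hand explains either the small steps or the larger ones.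

The compounds shown leave open whether an amine or a fluorine on the same aromatic carbon would also stay within the scatter. They also leave open whether an amine in place of the hydroxy group would alter the number.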